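Adding chloro to the phenyl group of compound 3

The source may hold more compounds than are shown below. What is called first, only, known or untested is meant among the compounds shown, and "the series" means these compounds.

Measured in a functional assay on HeLa cells (Homo sapiens) for inhibition, read by MTT assay, with a stated time of 48 h; a lower number here means a stronger inhibitor of growth, a higher number a weaker inhibitor of growth:
compound 1 `Cn1cc(C2CC(c3ccccc3)=NN2C(=O)c2cccnc2)c2ccccc21`: > 10000 nM (a limit, not a number)
compound 2 `Cc1ccc(C(=O)N2N=C(c3ccccc3)CC2c2cn(C)c3ccccc23)cn1`: 2390 nM
compound 3 `Cn1cc(C2CC(c3ccccc3)=NN2C(=O)c2cccnc2)c2cc(Br)ccc21`: 1730 nM

In this assay compound 3 gives 1730 nM and compound 2 gives 2390 nM, two values within the scatter of each other. Going by the values given here, the only other compound, compound 1, stands at a limit.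

Compound 4 `Cn1cc(C2CC(c3ccc(Cl)cc3)=NN2C(=O)c2cccnc2)c2cc(Br)ccc21` is compound 3 with one change, chloro in place of hydrogen on an aromatic carbon, which turns phenyl to 4-chlorophenyl.

Among the compounds with values here, two measured steps bear on this change. One is an at least 4.1-fold lower number from compound 1 to compound 2 (0.62 log units; beyond the scatter), with methyl in place of hydrogen on an aromatic carbon. The other is an at least 5.7-fold lower number from compound 1 to compound 3 (0.76 log units; beyond the scatter), with bromo in place of hydrogen on an aromatic carbon, and it is the closer in kind. Both lie beyond the scatter and both start from the limit. Neither touches the phenyl group, and compound 3 already carries its bromo, so they are only a loose guide. A modest step towards a lower number is therefore expected, not a large one.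

The expected change is a 2.3-fold lower number from compound 3 to compound 4 (0.36 log units; beyond the scatter).

For compound 4 the estimated value is 750 nM, with an expected range from 250 nM to 2500 nM.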

Compound 4, concentration for 50% growth inhibition: 5200 nM
Beside the measured number, compound 4's estimate is 6.9-fold (0.84 log units) below it; measured number outside the range, above it.
By their numbers in this assay, from the lowest: compounds 3 and 2 (each within the scatter of the next); then compound 4. At a limit, above all of these: compound 1.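

In this assay, the phenyl group proves sensitive to substitution: swapping it for 4-chlorophenyl gives a 3.0-fold higher number from compound 3 to compound 4 (0.48 log units; beyond the scatter) and is the only measured change at this position among the compounds shown. This step runs against the two earlier replacements of hydrogen on an aromatic carbon elsewhere in the molecule, an at least 4.1-fold lower number from compound 1 to compound 2 (0.62 log units; beyond the scatter) with methyl and an at least 5.7-fold lower number from compound 1 to compound 3 (0.76 log units; beyond the scatter) with bromo, so such a replacement does not lower the number wherever it is made. Those two earlier steps share a starting point in compound 1, so their sizes are bounded rather than exact, and they could say little about the phenyl group: the limit of > 10000 nM in this assay, at which 1 of the 4 values shown sits.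

The compounds shown leave open whether this rise belongs to chloro alone or would also follow a fluoro, a methoxy or an amine at the same place on the phenyl group. They also leave open whether chloro would act in the same way without the bromo of compound 3, on the core of compound 1, and they give no way of telling what lies behind the step.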